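The source may report more compounds than this note shows. Statements on the series, on what has been measured and on what is new or still open speak of the compounds shown alone.

In a functional assay on NCI-H460 cells (Homo sapiens) for cytotoxicity, read by MTT assay, with a stated time of 72 h (on this read-out lower numbers stand for stronger inhibition and higher numbers for weaker inhibition), three compounds have been measured. Compound 1 `CN(C)CCn1cnnc1-c1cc(Oc2ccc(NC(=O)N/N=C/c3ccc(O)c(F)c3)cc2F)ccn1` gives 2620 nM. Compound 2 `CN(C)CCn1cnnc1-c1cc(Oc2ccc(NC(=O)N/N=C/c3ccc(O)c(O)c3)cc2F)ccn1` gives 1930 nM. Compound 3 `CN(C)CCn1cnnc1-c1cc(Oc2ccc(NC(=O)N/N=C/c3ccc(F)cc3)cc2F)ccn1` gives 1980 nM.

Compound 1 has the highest of the three numbers, but its steps to the other two, a 1.4-fold lower number from compound 1 to compound 2 (0.13 log units; within the scatter) and a 1.3-fold lower number from compound 1 to compound 3 (0.12 log units; within the scatter), both stay within the scatter, as does a 1.0-fold higher number from compound 2 to compound 3 (0.01 log units; within the scatter). Compound 4 `COc1cc(/C=N/NC(=O)Nc2ccc(Oc3ccnc(-c4nncn4CCN(C)C)c3)c(F)c2)ccc1O` differs from compound 1 in one place: methoxy in place of fluoro on an aromatic carbon. For the measured compounds named here, the closest precedent is the exchange at the same aromatic carbon from compound 1 to compound 2, which moved the number only within the scatter, and the wider swaps of the aryl group did no more. Compound 4 is therefore expected to show no step beyond the scatter in this assay, a 1.2-fold lower number from compound 1 to compound 4 (0.08 log units; within the scatter). The value of compound 4 is estimated at 2200 nM, within 1000 nM to 4800 nM.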

Compound 4, half-maximal inhibitory concentration: 57 nM
Compound 4: the middle estimate sits 39-fold (1.59 log units) above what was measured, outside the stated range (below it).
By their numbers in this assay, from the lowest: compound 4; then compounds 2, 3 and 1 (each within the scatter of the next).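

In this assay, for the compounds shown here, this position on the aromatic ring, ortho to a hydroxy group, proves far more sensitive than the earlier compounds suggested: methoxy in place of fluoro gives a 46-fold lower number from compound 1 to compound 4 (1.66 log units; beyond the scatter). Methyl in place of hydrogen on the oxygen gives a 34-fold lower number from compound 2 to compound 4 (1.53 log units; beyond the scatter), and 4-hydroxy-3-methoxyphenyl in place of 4-fluorophenyl gives a 35-fold lower number from compound 3 to compound 4 (1.54 log units; beyond the scatter). Nothing available explains this large step. On these data alone, whether ethoxy at this position would hold the low number remains open, as does whether methoxy would do so with an amine in place of the hydroxy group.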